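A few compounds are considered here, and "the series" means these few. Any claim that something is new, unique, unknown or untested is made for them only; others in the source may bear on it.

Compound 1 `CCCCCCCNc1ccc(C(=O)C2CC2c2ccc(Cl)cc2)cc1` is examined in an ADME assay on Vero cells (Chlorocebus sabaeus) for cytotoxicity, with a stated time of 72 h (a lower number here means that less compound is tolerated, a higher number that more compound is tolerated), where compound 1 gives 398 ug/mL. Its companion compound 2 `O=C(c1ccc(N2CCCC2)cc1)C1CC1c1ccc(Cl)cc1` gives 431 ug/mL in this assay. Among these two numbers compound 1 holds the lowest, and the single step that joins them, a 1.1-fold higher number from compound 1 to compound 2 (0.03 log units; within the scatter), lies within the scatter. The new compound 3 `CCCCCCCC/C=C\CCCCCCCCNc1ccc(C(=O)C2CC2c2ccc(Cl)cc2)cc1` differs from compound 1 by undec-2-en-1-yl in place of hydrogen on a saturated chain carbon, seven bonds along the chain from a nitrogen on an aromatic ring, a change on the saturated chain carbon seven bonds along the chain from the nitrogen on the aromatic ring. Among the compounds with values here, no measured step of the same kind exists: the one step on record, from compound 1 to compound 2, swaps the group on the aromatic nitrogen rather than lengthening the chain, and it moved this assay by nothing beyond the scatter. On that slim basis compound 3 is expected to show a step of a 1.1-fold lower number from compound 1 to compound 3 (0.06 log units; within the scatter), that is, no change beyond the scatter, with wide uncertainty. Compound 3 is therefore estimated at 350 ug/mL, within a range from 120 ug/mL to 700 ug/mL.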

Compound 3, half-maximal cytotoxic concentration: 393 ug/mL
Estimate against measurement, compound 3: 1.1-fold (0.05 log units) below, and the stated range covers the measured number.
By their numbers in this assay, from the lowest: compounds 3, 1 and 2 (each within the scatter of the next).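

The step in this assay, which is a 1.0-fold lower number from compound 1 to compound 3 (0.01 log units; within the scatter), shows that undec-2-en-1-yl, with its 11 carbon atoms and one double bond, can stand on this saturated chain carbon, seven bonds along the chain from a nitrogen on an aromatic ring, without a move beyond the scatter. Within the data shown here, the earlier step had exchanged the whole group on the aromatic nitrogen, so this is the first reading of a change on the chain itself, and the only reading for this position. No measurement offers an explanation for this result.

From the compounds shown here alone, whether an amine or a carboxylic acid on this same carbon would also stay within the scatter in this assay remains open. The same holds for a phenyl group there.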